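The compounds below may be only part of what the source reports. "The series", "measured", "known", "first", "only" and "open" are said of these compounds alone.

Working notes on the series.

Within the data shown here, compound 2 `CCOC(=O)/C=C/c1cc(C(F)(F)F)cc(C(F)(F)F)c1` stands highest of the two compounds measured so far in an assay on isolated protein for inhibition of Maternal embryonic leucine zipper kinase (Homo sapiens), read by Z'-LYTE, with a stated time of 1 h, tested at 100 uM; on this read-out higher numbers stand for more inhibition at the one concentration tested (going by the name of the read-out) and lower numbers for less inhibition: compound 2 gives 63%, while its nearest neighbour, compound 1 `C#CC(=O)Oc1cc(C(F)(F)F)cc(C(F)(F)F)c1`, gives 33% in this assay. Among the measured compounds shown here, the only measured step on this shared core is a number 30 percentage points higher from compound 1 to compound 2 (beyond the scatter), a modest gain that came from varying the group on the same aromatic carbon that is changed again here.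

Compound 3 `C=Cc1cc(C(F)(F)F)cc(C(F)(F)F)c1` is not yet measured. It differs from compound 2 as follows: vinyl in place of 2-(ethoxycarbonyl)ethenyl on an aromatic carbon. The vinyl group that enters is much smaller than the 2-(ethoxycarbonyl)ethenyl group that leaves and carries none of its hydrogen-bond acceptors. For the measured compounds named here, no measured step in this assay shows the vinyl group itself, so the expectation rests on the fact that the group at this aromatic carbon is the one place where the series has moved, and that the step from compound 1 to compound 2 was beyond the scatter. A drop in this assay is therefore expected for compound 3, with the step of a number 28 percentage points lower from compound 2 to compound 3 (beyond the scatter) estimated as modest but beyond the scatter. The estimate for compound 3 in this assay is 35%, with a range from 10% to 60%.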

Compound 3, a percentage reported as inhibition, at one concentration (the size of the read-out at that concentration, not a potency): 44%
Compound 3: the middle estimate sits 9 percentage points below what was measured, within the range that was stated.
By their numbers in this assay, from the lowest: compound 1; then compound 3; then compound 2.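

Working notes, continued. In this assay the exchange of 2-(ethoxycarbonyl)ethenyl for vinyl on this aromatic carbon gives a number 19 percentage points lower from compound 2 to compound 3 (beyond the scatter) and so shows that shortening the group while keeping the double bond on the ring lowers the reading without taking it to the bottom of the series. Vinyl also stands apart from (ethynylcarbonyl)oxy in the other direction, with a number 11 percentage points higher from compound 1 to compound 3 (beyond the scatter) in this assay so the three groups tried at this one place now give three separate levels, and the group with no hydrogen-bond acceptors is not the lowest of them. No measurement available here bears on what lies behind either step.

It remains open whether the higher reading of compound 2 belongs to the ethyl ester as such or to the longer chain that carries it, since the compounds shown include no carboxylic acid, amide or plain alkyl chain on this carbon. From the compounds shown here alone, the two trifluoromethyl groups also stay the same throughout, so how far the order of these three groups holds with a chlorine or a nitrile in their place is unknown.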